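This account rests on a few compounds, and the source may have more. Where it says the series, first, only, none or still open, it means among the compounds named here.

Working notes, an ADME assay on HOS cells (Homo sapiens) for cytotoxicity, read by luminescence and ATP content, with a stated time of 48 h; a lower number here means that less compound is tolerated, a higher number that more compound is tolerated:

- Compound 1 `COC(=O)CNc1c(C(=O)NCc2ccc(F)cc2F)c(=O)n(O)c2nc(OC)ccc12`: 12000 nM.
- Compound 2 `O=C(NCc1ccc(F)cc1F)c1c(O)c2cc(CCCCCO)cnc2n(O)c1=O`: > 250000 nM, a limit.
- Compound 3 `COC(=O)CNc1c(C(=O)NCc2ccc(F)cc2F)c(=O)n(O)c2ncc(CCCCCO)cc12`: > 250000 nM, a limit.

Compound 3 has no readable number, only its limit of > 250000 nM. It sits at the limit of > 250000 nM in this assay, at which 2 of the 3 values shown sit.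

Compound 4 `O=C(NCc1ccc(F)cc1F)c1c(NCCO)c2cc(CCCCCO)cnc2n(O)c1=O` differs from compound 3 by hydroxymethyl in place of methoxycarbonyl on a saturated chain carbon bound to a nitrogen on an aromatic ring. Cut one bond further out, this is (methoxycarbonyl)methyl to 2-hydroxyethyl.

Among the measured compounds shown here, no measured step covers this exact change. The nearest is a step that the two limits leave unreadable from compound 2 to compound 3, which gives no size to carry over. Compound 3 shares its ((methoxycarbonyl)methyl)amino group with compound 1, which gives 12000 nM, so a readable number for compound 4 in this assay cannot be ruled out.

No step beyond the usual scatter, in either direction, is expected, and the expected change is an at least 1.2-fold lower number from compound 3 to compound 4 (0.09 log units; that floor lies within the scatter). For compound 4 the estimated value is 200000 nM, with an expected range of 50000 nM to 500000 nM.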

Compound 4, half-maximal cytotoxic concentration: > 250000 nM
Compound 4: only a limit was reported; the forecaster's own chance of this, stated with the estimate: 60%; at least 1.2-fold (0.09 log units) between middle value and limit.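

In this assay compound 4 gives > 250000 nM, which is a limit, so the steps to it from compound 2 and compound 3 cannot be read: the limit of > 250000 nM in this assay, at which 3 of the 4 values shown sit.

The compounds shown leave open how far compound 2, compound 3 and compound 4 differ from one another.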